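This account rests on a few compounds, and the source may have more. Where it says the series, first, only, none or still open, it means among the compounds named here.

Compound 1 `C=CCn1c(=O)/c(=C\c2cccc(Cl)c2)[nH]c(=O)/c1=C\c1ccccc1OC`: 4500 nM
Compound 2 `C=CCn1c(=O)/c(=C\c2ccc(Cl)c(Cl)c2)[nH]c(=O)/c1=C\c1ccccc1OC`: "not active" (no number reported)

In a functional assay on HL-60 cells (Homo sapiens) for cytotoxicity, read by CCK-8 assay, with a stated time of 72 h (on this read-out lower numbers stand for stronger inhibition and higher numbers for weaker inhibition), compound 1 gives 4500 nM. Compound 2 carries a second chlorine and in this assay compound 2 is reported as "not active" (no number reported), so no number stands for it. Compound 3 `C=CCn1c(=O)/c(=C\c2ccc(Cl)c(Cl)c2)[nH]c(=O)/c1=C\c1ccccc1` differs from compound 2 by hydrogen in place of methoxy on an aromatic carbon. Among the compounds with values here, with no measured step of this kind to lean on, and a starting point that gave no number, the size and direction of the change cannot be read from the data. Compound 3 is expected to stay weak, with an estimated value of 20000 nM in a range from 5000 nM to 80000 nM, and a real chance that only a limit is reported.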

Compound 3, half-maximal inhibitory concentration: "not active" (no number reported)
Nothing numeric was reported for compound 3; the estimate stays without a comparison.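

Within the data shown here, compound 2 and compound 3 are both reported as not active, without a number, so no step between them can be read, and no supporting data bear on this result. As far as these compounds go, whether changing 2-methoxyphenyl to phenyl alters potency remains open.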